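A few compounds are considered here, and "the series" means these few. Any claim that something is new, unique, unknown or untested is made for them only; others in the source may bear on it.

In a functional assay on DU-145 cells (Homo sapiens) for inhibition, read by MTT assay, with a stated time of 72 h (on this read-out lower numbers stand for stronger inhibition and higher numbers for weaker inhibition), three compounds with a shared core have been measured so far. Compound 1 (`COc1ccc(N2CCN(C3=CC(=O)c4ccccc4C3=O)CC2)cc1`) gives 46100 nM as its reading. Compound 2 (`COc1cc(OC)cc(N2CCN(C3=CC(=O)c4ccccc4C3=O)CC2)c1`) gives 14900 nM as its reading. Compound 3 (`COc1ccc(N2CCN(C3=CC(=O)c4ccccc4C3=O)CC2)cc1OC`) gives 17800 nM as its reading. Compound 3 therefore stands level with compound 2, the two lying within the usual scatter of each other, and clearly under compound 1.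

Compound 4 (`COc1cc(N2CCN(C3=CC(=O)c4ccccc4C3=O)CC2)cc(OC)c1OC`) has not been measured yet. It differs from compound 3 by methoxy in place of hydrogen on an aromatic carbon with methoxy in place of hydrogen on an aromatic carbon, ortho to a methoxy group, meta to a methoxy group and meta to a large group.

Among the compounds with values here, the one measured step of the same kind is a 2.6-fold lower number from compound 1 to compound 3 (0.41 log units; beyond the scatter) and counts as modest, though beyond the scatter. A single step is thin ground for a forecast, so in this assay a modest move toward a lower number is expected again, with no certainty that it will clear the scatter. The expected size is a 1.8-fold lower number from compound 3 to compound 4 (0.25 log units; within the scatter) on this reasoning. For compound 4 the estimated value is 10000 nM with an expected range from 4000 nM to 25000 nM as the likely span.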

Compound 4, half-maximal inhibitory concentration: 11600 nM
Beside the measured number, compound 4's estimate is 1.2-fold (0.06 log units) below it, within the range that was stated.
By their numbers in this assay, from the lowest: compounds 4, 2 and 3 (each within the scatter of the next); then compound 1.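

In this assay, methoxy in place of hydrogen at this new position gives a 1.5-fold lower number from compound 3 to compound 4 (0.19 log units; within the scatter), and the same kind of change on the other route into compound 4 gives a 1.3-fold lower number from compound 2 to compound 4 (0.11 log units; within the scatter), so neither step clears the scatter. Where the earlier compounds offered only one step of this change, and that one beyond the scatter, this position, ortho to a methoxy group and meta to a large group, accepts a further methoxy with no reading that can be told apart from the one before it. The change can now be compared on two cores, and the size of its effect cannot be said to differ between them: the same change on two cores in this assay, a 2.6-fold lower number (0.41 log units; beyond the scatter) from compound 1 to compound 3 and a 1.3-fold lower number (0.11 log units; within the scatter) from compound 2 to compound 4, 2.0-fold (0.30 log units) apart, within the scatter of two such steps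

The compounds shown carry only methoxy groups on this aromatic ring, so it remains open whether an amine, a carboxylic acid or a chlorine atom at the same position would move the reading beyond the scatter. On these data alone, it also remains open whether a longer chain, such as ethoxy in place of methoxy, would behave any differently here.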